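The source may hold more compounds than are shown below. What is called first, only, known or untested is meant among the compounds shown, and "the series" means these compounds.

Measured so far:
compound 1, `COc1cc(-c2cc(/C=C/C(=O)c3ccc(N)cc3)[nH]n2)cc(OC)c1OC`: 34800 nM
compound 2, `COc1ccc(-c2cc(/C=C/C(=O)c3ccc(OC)c(OC)c3)[nH]n2)cc1`: 22000 nM

Both values come from a functional assay on SF-295 cells (Homo sapiens) for inhibition, read by sulforhodamine B assay, with a stated time of 48 h; on this read-out lower numbers stand for higher toxicity in this test and higher numbers for lower toxicity in this test. Compound 1 shows the highest of the two numbers; compound 2 lies a little lower, but the gap between them is within the scatter, so the two cannot be ordered.

Compound 3, `COc1ccc(-c2cc(/C=C/C(=O)c3ccc(N)cc3)[nH]n2)cc1OC`, has not been measured. It differs from compound 1 in one place: hydrogen in place of methoxy on an aromatic carbon. A methoxy leaves and a hydrogen enters, on an aromatic carbon of a six-membered aromatic ring of carbon only, ortho to a methoxy group and meta to a large group.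

Going by the values given here, no step between measured compounds bears on this change, so the expected step is small. Compound 3 is expected to stay near compound 1, with the step of a 1.3-fold higher number from compound 1 to compound 3 (0.11 log units; within the scatter) expected to lie within the scatter or slightly toward a higher number. The estimate for compound 3 in this assay is 45000 nM, in the range 15000 nM to 140000 nM.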

Compound 3, concentration lethal to 50% of the cells: 42900 nM
Beside the measured number, compound 3's estimate is 1.0-fold (0.02 log units) above it; low and high end bracket the measured number.
By their numbers in this assay, from the lowest: compounds 2, 1 and 3 (each within the scatter of the next).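

In this assay the series now has its first pair that differs in one place, and hydrogen in place of methoxy gives a 1.2-fold higher number from compound 1 to compound 3 (0.09 log units; within the scatter) which lies within the scatter. At this aromatic carbon, ortho to a methoxy group and meta to a large group, the methoxy can therefore be lost with no readable change in the number on this read-out. Nothing available accounts for this result.

From the compounds shown here alone, whether another group at this place, such as a hydroxyl, a fluorine or a carboxylic acid, would give a step beyond the scatter remains open. Also open, going by these compounds, is whether hydrogen in place of a further methoxy on the same ring would leave the number as unchanged as this step did.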